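Extending the chain on the ring nitrogen of compound 3

The compounds below may be only part of what the source reports. "The series", "measured", "known", "first", "only" and "open" are said of these compounds alone.

Of the compounds shown here, three sharing one core have been measured in an ADME assay on cells (Hepatocyte, Rattus norvegicus) for metabolic stability; on this read-out lower numbers stand for slow clearance and higher numbers for fast clearance. Compound 1 `CC(C)Cn1cc(-c2ccnc3[nH]c(C4CCN(CC(=O)N(C)C)CC4)cc23)ccc1=O` gives 6.6 uL/min. Compound 2 `CN(C)C(=O)CN1CCC(c2cc3c(-c4ccc(=O)n(C5CCOCC5)c4)ccnc3[nH]2)CC1` gives 2.3 uL/min, and compound 3 `CC(C)n1cc(-c2ccnc3[nH]c(C4CCN(CC(=O)N(C)C)CC4)cc23)ccc1=O` gives 2.3 uL/min. Compound 3 thus sits level with compound 2 at the digits shown, and the two together are the lowest of the three, while a 2.9-fold lower number from compound 1 to compound 3 (0.46 log units; beyond the scatter) marks the only step beyond the scatter among them.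

Compound 4 `CN(C)C(=O)CN1CCC(c2cc3c(-c4ccc(=O)n(CCC5CCOCC5)c4)ccnc3[nH]2)CC1` differs from compound 3 in one place: 2-(oxan-4-yl)ethyl in place of isopropyl on an aromatic nitrogen.

For the measured compounds named here, two measured steps bear on this change. Swapping isobutyl for isopropyl gave a 2.9-fold lower number from compound 1 to compound 3 (0.46 log units; beyond the scatter), so a shorter chain went with slower clearance, and the reverse direction points toward faster clearance when the chain grows. Swapping oxan-4-yl for isopropyl gave no change at the digits printed from compound 2 to compound 3 (within the scatter), so the ring itself made no difference beyond the scatter. Because a 2.9-fold lower number from compound 1 to compound 3 (0.46 log units; beyond the scatter) came with the shorter chain and the new group is the longer one, a modest rise is expected for compound 4, about a 2.2-fold higher number from compound 3 to compound 4 (0.34 log units; beyond the scatter). Compound 4 is estimated at 5 uL/min, within a range from 2 uL/min to 12 uL/min.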

Compound 4, intrinsic clearance in a liver preparation (reported as CLH), per the amount of preparation that the assay uses: 14 uL/min
The estimate for compound 4 lay 2.8-fold (0.45 log units) below the measured number; measured number outside the range, above it.
By their numbers in this assay, from the lowest: compounds 2 and 3 (each within the scatter of the next); then compound 1; then compound 4.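

In this assay the oxan-4-yl ring alone does not set the number: attached directly to the aromatic nitrogen it sits level with isopropyl, yet 2-(oxan-4-yl)ethyl gives a 6.1-fold higher number from compound 2 to compound 4 (0.78 log units; beyond the scatter). Against the small isopropyl group the same change gives a 6.1-fold higher number from compound 3 to compound 4 (0.78 log units; beyond the scatter), which shows that this position tolerates less extension than the earlier compounds suggested. Among these four compounds, the two whose groups reach the nitrogen through a chain carry the highest numbers, with none going against this, and the longer group gives a 2.1-fold higher number from compound 1 to compound 4 (0.33 log units; beyond the scatter).

Nothing here explains the rise. As far as these compounds go, it remains open whether chain length or the ring at its end matters more, which a plain pentyl chain or an (oxan-4-yl)methyl group on the same nitrogen could help separate.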